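Removing the Bromo Group From a Weak Cytotoxic Compound

The source may hold more compounds than are shown below. What is called first, only, known or untested is meant among the compounds shown, and "the series" means these compounds.

- Compound 1 `COc1ccc2c(/C=C(\C#N)C(=O)c3c[nH]c4cc(OC)ccc34)c[nH]c2c1`: > 50000 nM (a limit)
- Compound 2 `N#C/C(=C\c1cn(Cc2ccc(Cl)cc2)c2ccc(Br)cc12)C(=O)c1c[nH]c2ccccc12`: 37700 nM
- Compound 3 `COc1ccc2[nH]cc(C(=O)/C(C#N)=C/c3c[nH]c4cc(F)ccc34)c2c1`: > 50000 nM (a limit)
- Compound 4 `N#C/C(=C\c1cn(Cc2ccc(Cl)cc2)c2ccccc12)C(=O)c1c[nH]c2ccccc12`: not yet measured

Among the compounds with values here, in a functional assay on MIA PaCa-2 cells (Homo sapiens) for cytotoxicity, read by WST assay, with a stated time of 24 h (a lower number here means a stronger inhibitor, a higher number a weaker inhibitor), compound 2 gives 37700 nM, the only actual number among the measured compounds. Compound 1 gives > 50000 nM, which is a limit and not a number. Compound 3 gives > 50000 nM, which is also a limit. Compound 4 differs from compound 2 at one place: hydrogen in place of bromo on an aromatic carbon. This puts hydrogen in place of bromo on an aromatic carbon. Within the data shown here, no measured pair shows the effect of this change, so the expectation is uncertain. No shift beyond the scatter is expected, with any drift towards weaker inhibition, and the estimated step is a 1.3-fold higher number from compound 2 to compound 4 (0.10 log units; within the scatter). For compound 4, the expected value is 48000 nM, with an estimated range of 24000 nM to 95000 nM.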

Compound 4, half-maximal inhibitory concentration: > 50000 nM
Compound 4 ended at the assay's limit (the forecaster's own chance of this, stated with the estimate: 55%); middle value at least 1.0-fold (0.01 log units) from the limit.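

Within the data shown here, replacing bromo with hydrogen on this aromatic carbon gives the first readable step for this change in this assay: an at least 1.3-fold higher number from compound 2 to compound 4 (0.12 log units; that floor lies within the scatter). Since that floor lies within the scatter, this pair neither shows that the bromo group matters here nor rules it out. The true size of the step cannot be read, because compound 4 gives only a limit: the limit of > 50000 nM in this assay, at which 3 of the 4 values shown sit.

As far as these compounds go, what an amine or a carboxylic acid on this carbon would do to the number remains open. So does whether any group here could give a clearly lower number than compound 2.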